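Cyano for ethyl on the aniline ring of compound 1

This account rests on a few compounds, and the source may have more. Where it says the series, first, only, none or still open, it means among the compounds named here.

Compound 1 `CCc1cc(N)ccc1-c1nc2ccccc2s1` gives in a functional assay on MDA-MB-468 cells (Homo sapiens) for inhibition (on this read-out lower numbers stand for stronger inhibition and higher numbers for weaker inhibition), a value of < 0.1 nM, which is a limit of the assay rather than a number.
Compound 2 `Cc1cc(N)cc(Cl)c1-c1nc2ccccc2s1` gives in this assay a value of > 1 nM, also a limit.
Compound 3 `Nc1cc(Cl)c(-c2nc3ccccc3s2)c(Cl)c1` gives in this assay a value of < 0.1 nM, again a limit.

Compound 1 thus sits at the lower limit of this assay, as stated in the limit of < 0.1 nM in this assay, at which 2 of the 3 values shown sit; only compound 2 stands at the upper limit described in the limit of > 1 nM in this assay, at which 1 of the 3 values shown sits. Compound 4 `N#Cc1cc(N)ccc1-c1nc2ccccc2s1` differs from compound 1 by cyano in place of ethyl on an aromatic carbon.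

Among the measured compounds shown here, the one measured step, an at least 10-fold lower number from compound 2 to compound 3 (1.00 log units; beyond the scatter), concerns chloro in place of methyl, and both of its values are limits, so it does not directly speak to cyano in place of ethyl. For the measured compounds named here, no measured pair shows a nitrile. Given that compound 1 already stands at a limit, compound 4 is expected to remain a potent inhibitor, but a somewhat higher number is estimated to allow for the change, giving an at least 3.0-fold higher number from compound 1 to compound 4 (0.47 log units; beyond the scatter) in this assay. Compound 4 is therefore estimated at 0.3 nM, with a range from 0.05 nM to 3 nM.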

Compound 4, half-maximal inhibitory concentration: < 0.1 nM
Compound 4 was reported as a limit (the forecaster's own chance of this, stated with the estimate: 35%); middle value at least 3.0-fold (0.47 log units) from the limit.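

Compound 1 and compound 4 both sit at the same limit of the assay, so the size of the step between them cannot be read: the limit of < 0.1 nM in this assay, at which 3 of the 4 values shown sit.

The compounds shown leave open how far apart compound 1 and compound 4 really lie, and whether cyano in place of ethyl changes inhibition at all in this assay.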